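The source may report more compounds than this note shows. Statements on the series, on what has been measured and on what is new or still open speak of the compounds shown alone.

Measured so far:
Compound 1 `COC1=C(C)C(=O)/C(=C(O)/C=C/c2ccc(C)cc2)C(=O)C1(C)C` gives 5.1 ug/mL
Compound 2 `CCC1=C(OC)C(CC)(CC)C(=O)C(C(=O)/C=C/c2ccccc2)=C1O` gives 5.4 ug/mL

For the measured compounds named here, in a functional assay on A-431 cells (Homo sapiens) for cytotoxicity (a lower number here means that less compound is needed, a higher number that more compound is needed for the effect), compound 2 gives 5.4 ug/mL and stands level, within the usual scatter, with compound 1 at 5.1 ug/mL in the only comparison available. Compound 3 `CCC1=C(OC)C(CC)(CC)C(=O)C(C(=O)/C=C/c2ccc(C)cc2)=C1O` has not yet been measured. It differs from compound 2 in one place. The change is methyl in place of hydrogen on an aromatic carbon and it reads as phenyl to 4-methylphenyl. Going by the values given here, no step between measured compounds shows what such a change does in this assay so nothing measured gives it a size. Among the compounds with values here, with only two values to go on, no shift beyond the scatter is expected in either direction. The expected 1.1-fold lower number from compound 2 to compound 3 (0.03 log units; within the scatter) is small and stays within the scatter. Compound 3 is estimated at 5 ug/mL and is expected to fall between 2.5 ug/mL and 10 ug/mL.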

Compound 3, concentration for half-maximal effect: 10.3 ug/mL
Beside the measured number, compound 3's estimate is 2.1-fold (0.31 log units) below it; the measured number lies above the stated range.
By their numbers in this assay, from the lowest: compounds 1, 2 and 3 (each within the scatter of the next, the first and the last beyond it).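

In this assay, for the compounds shown here, the methyl placed on the aromatic carbon para to a large group, taking phenyl to 4-methylphenyl, gives a 1.9-fold higher number from compound 2 to compound 3 (0.28 log units; within the scatter) and this is the first size available for this change at this position. The step stays within the scatter, so the added methyl is not shown to alter the cytotoxicity read-out, and this one pair gives no direction for the change. Nothing available bears on the reason for this result.

As far as these compounds go, whether a different group on this same aromatic carbon, such as methoxy, chlorine, an amine or a carboxylic acid, would move the number beyond the scatter stays open. From the compounds shown here alone, compound 1 also carries 4-methylphenyl but differs from compound 3 in more than one place, so whether the methyl has the same effect on the core of compound 1 also stays open.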